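Removing a Methoxy Group: Expectation for Compound 3

A few compounds are considered here, and "the series" means these few. Any claim that something is new, unique, unknown or untested is made for them only; others in the source may bear on it.

Measured so far:
Compound 1 `COc1ccc(-c2[nH]c3ccccc3c2/C=C(\C#N)S(=O)(=O)c2ccccc2)cc1` — in a functional assay on SR cells (Homo sapiens) for inhibition, read by sulforhodamine B assay, with a stated time of 48 h (on this read-out higher numbers stand for weaker inhibition of growth and lower numbers for stronger inhibition of growth), compound 1 gives 350 nM.
Compound 2 `COc1ccc(-c2[nH]c3ccc(OC)cc3c2/C=C(\C#N)S(=O)(=O)c2ccccc2)cc1` — in this assay compound 2 gives 305 nM.

Compound 2 stands at the lowest of the two numbers, but the gap to compound 1 is small: a 1.1-fold lower number from compound 1 to compound 2 (0.06 log units; within the scatter). So the two compounds cannot be told apart on this read-out.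

Compound 3 `COc1ccc2[nH]c(-c3ccccc3)c(/C=C(\C#N)S(=O)(=O)c3ccccc3)c2c1` differs from compound 2 in one place: hydrogen in place of methoxy on an aromatic carbon. Among the compounds with values here, only one measured step exists, and it concerns a methoxy group at a different place from the one removed here; that step, a 1.1-fold lower number from compound 1 to compound 2 (0.06 log units; within the scatter), did not move the number beyond the scatter. Within the data shown here, there is no measured pair that adds or removes a methoxy at the place changed in compound 3, so the expectation rests on the general picture that one methoxy change so far left the number about where it was. On that basis the expected step in this assay is small, with no clear direction: a 1.2-fold higher number from compound 2 to compound 3 (0.10 log units; within the scatter). Compound 3 is therefore estimated at 380 nM, with a plausible range from 150 nM to 1000 nM.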

Compound 3, concentration for 50% growth inhibition: 2200 nM
Compound 3: the middle estimate sits 5.8-fold (0.76 log units) below what was measured; the whole stated range lies below it.
By their numbers in this assay, from the lowest: compounds 2 and 1 (each within the scatter of the next); then compound 3.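

In this assay, within the data shown here, changing 4-methoxyphenyl to phenyl gives a 7.2-fold higher number from compound 2 to compound 3 (0.86 log units; beyond the scatter), which means weaker inhibition of growth, so the methoxy at this place, para to a large group, counts in a way the earlier compounds could not reveal. Among these compounds, the only earlier methoxy change, at a different place on the molecule, gave a 1.1-fold lower number from compound 1 to compound 2 (0.06 log units; within the scatter) and stayed within the scatter, so two methoxy groups on the same series need not matter equally, and the place of the group has to be taken into account. Nothing here explains why this methoxy matters, since no measurement on these compounds bears on the cause.

These compounds cannot show whether it is the methoxy itself that counts at this place, or whether a hydroxyl, an amine, a fluorine or a longer chain such as ethoxy would serve as well or better. Among the compounds shown here, the removal was also seen only with the second methoxy on the core in place, so whether the same loss follows on the core of compound 1 remains open.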